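The source may hold more compounds than are shown below. What is called first, only, known or untested is meant among the compounds shown, and "the series" means these compounds.

Measured compounds:
- compound 1, `O=S(=O)(c1ccc(F)cc1)c1cnc2c(F)cccc2c1-c1cccc(F)c1`, 1.56 mL/min
- compound 2, `O=S(=O)(c1cccc(F)c1)c1cnc2c(F)cccc2c1-c1cccc(F)c1`, 1.14 mL/min
- compound 3, `O=S(=O)(c1cc(Cl)cc(Cl)c1)c1cnc2c(F)cccc2c1-c1cccc(F)c1`, 1.08 mL/min

In an ADME assay on microsomes from liver (Homo sapiens) for metabolic stability, tested at 2.5 uM (a lower number here means slower removal, a higher number faster removal of the compound), compound 1 gives the highest of the three numbers, yet its steps to the others, a 1.4-fold lower number from compound 1 to compound 2 (0.14 log units; within the scatter) and a 1.4-fold lower number from compound 1 to compound 3 (0.16 log units; within the scatter), both lie within the scatter, as does a 1.1-fold lower number from compound 2 to compound 3 (0.02 log units; within the scatter). Compound 4, `O=S(=O)(c1ccc(F)cc1)c1cnc2c(F)cccc2c1-c1cccc(Cl)c1`, differs from compound 1 by chloro in place of fluoro on an aromatic carbon. Among the compounds with values here, every measured step instead changes the group on the sulfonyl sulfur, so no measured pair speaks directly to this change; those steps were all small, and nothing in the set points to a direction for a halogen swap on the other ring. A step of about a 1.1-fold higher number from compound 1 to compound 4 (0.04 log units; within the scatter) is therefore expected, within the scatter. Compound 4 is estimated at 1.7 mL/min, between 0.9 mL/min and 3.2 mL/min.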

Compound 4, intrinsic clearance in a liver preparation (reported as CLH), per the amount of preparation that the assay uses: 1.21 mL/min
The estimate for compound 4 lay 1.4-fold (0.15 log units) above the measured number; low and high end bracket the measured number.
By their numbers in this assay, from the lowest: compounds 3, 2, 4 and 1 (each within the scatter of the next).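

Within the data shown here, compound 4 changes the aromatic ring that the earlier compounds held constant, and in this assay chloro in place of fluoro at this position comes with a 1.3-fold lower number from compound 1 to compound 4 (0.11 log units; within the scatter). This halogen swap on the 3-fluorophenyl group therefore stays within the scatter, as the changes on the sulfonyl sulfur did. Nothing at hand offers an account of this result.

From the compounds shown here alone, how an amine, a carboxylic acid or a methoxy group at this position would behave in this assay remains open. Also open, going by these compounds, is whether the same swap would read alike with a different group on the sulfonyl sulfur.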